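The source may hold more compounds than are shown below. What is called first, only, known or untested is meant among the compounds shown, and "the series" means these compounds.

The compounds here share one core, shown with compound 1 `Cc1ccc(C2=NN(C3=NC(c4ccccc4)CS3)C(c3ccc4ccccc4c3)C2)cc1`, compound 2 `Cc1ccc(C2=NN(C3=NC(c4ccccc4)CS3)C(c3ccc4ccccc4c3)C2)cc1C` and compound 3 `O=C1CSC(N2N=C(c3ccc(Cl)cc3)CC2c2ccc3ccccc3c2)=N1`. In a functional assay on HepG2 cells (Homo sapiens) for inhibition, read by CCK-8 assay, with a stated time of 48 h (on this read-out lower numbers stand for stronger inhibition and higher numbers for weaker inhibition), compound 1 gives 14700 nM, compound 2 gives 7370 nM, and compound 3 gives 20400 nM. Among these three numbers compound 3 carries the highest; its gap to compound 1 lies within the scatter, its gap to compound 2 beyond it. Among the compounds with values here, the only step measured between two compounds differing in one place, a 2.0-fold lower number from compound 1 to compound 2 (0.30 log units; within the scatter), concerns a methyl added to an aromatic carbon. Compound 4 `Clc1ccc(C2=NN(C3=NC(c4ccccc4)CS3)C(c3ccc4ccccc4c3)C2)cc1` comes from compound 3 by a different change: a group of 11 heavy atoms (9 carbon, 1 nitrogen, 1 sulfur; one five-membered non-aromatic ring with 2 hetero atoms, one six-membered aromatic ring of carbon only) in place of a group of 6 heavy atoms (3 carbon, 1 nitrogen, 1 oxygen, 1 sulfur; one five-membered non-aromatic ring with 2 hetero atoms), on an amine nitrogen in a ring. Within the data shown here, no measured step tests this exchange, since compound 3 is the only compound bearing the group that leaves, and compound 1 differs from compound 3 in two places at once. The numbers of compound 1 and compound 3 sit close to each other, so the expected step is a 1.6-fold lower number from compound 3 to compound 4 (0.20 log units; within the scatter). Compound 4 is therefore estimated at 13000 nM in this assay, between 4500 nM and 40000 nM.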

Compound 4, half-maximal inhibitory concentration: 22100 nM
Estimate against measurement, compound 4: 1.7-fold (0.23 log units) below, within the range that was stated.
By their numbers in this assay, from the lowest: compounds 2, 1, 3 and 4 (each within the scatter of the next, the first and the last beyond it).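

In this assay, the first direct test of this exchange on the amine nitrogen in a ring gives a 1.1-fold higher number from compound 3 to compound 4 (0.03 log units; within the scatter), so the group of 11 heavy atoms, with its added six-membered aromatic ring of carbon only, and the group of 6 heavy atoms cannot be told apart here. Chloro in place of methyl on an aromatic carbon gives a 1.5-fold higher number from compound 1 to compound 4 (0.18 log units; within the scatter), which also stays within the scatter. The full exchange of 4-chlorophenyl for 3,4-dimethylphenyl gives a 3.0-fold higher number from compound 2 to compound 4 (0.48 log units; beyond the scatter), a modest step and the only one-place step among these compounds that goes beyond the scatter.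

Still open, from the compounds shown here alone, is how an amine or a carboxylic acid would read in place of the chloro on that phenyl ring. The data shown offer no explanation for any of these steps.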